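The source may hold more compounds than are shown below. What is called first, only, known or untested is meant among the compounds shown, and "the series" means these compounds.

Within the data shown here, in an ADME assay on KB cells (Homo sapiens) for cytotoxicity, read by MTT assay, with a stated time of 72 h (on this read-out lower numbers stand for stronger inhibition and higher numbers for weaker inhibition), compound 3 (`COc1ccc(C2=C(c3cc(OC)c(OC)c(OC)c3)C(=O)C(OC(C)=O)C2)cc1Cl`) gives 64 ug/mL and sits level with compound 2 (`COc1ccc(C2=C(c3cc(OC)c(OC)c(OC)c3)C(=O)C(OC(C)=O)C2)cc1`) at 72 ug/mL on the numbers so far. The two are separated by a 1.1-fold lower number from compound 2 to compound 3 (0.05 log units; within the scatter) and cannot be told apart. Compound 1 (`COc1ccc(C2=C(c3cc(OC)c(OC)c(OC)c3)C(=O)C(OC(C)=O)C2)cc1OC(C)C`) reads > 100 ug/mL as a limit of the assay and not a number. Its steps are floors only: an at least 1.3-fold lower number from compound 1 to compound 2 (0.14 log units; that floor lies within the scatter) and an at least 1.5-fold lower number from compound 1 to compound 3 (0.19 log units; that floor lies within the scatter) on the same aromatic carbon.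

Compound 4 (`COc1ccc(C2=C(c3cc(OC)c(OC)c(OC)c3)C(=O)C(OC(C)=O)C2)cc1O`) carries hydroxy in place of chloro on an aromatic carbon, ortho to a methoxy group (hydroxy in place of chloro on an aromatic carbon). Among the measured compounds shown here, no compound measured so far carries hydroxy at this carbon, and the measured steps cover only hydrogen, chloro and isopropoxy. Taking compound 3 at 64 ug/mL as the starting point, and a 1.1-fold lower number from compound 2 to compound 3 (0.05 log units; within the scatter) as the only exact step size available, no step beyond the scatter is expected in this assay for this change. Hydroxy has no measured precedent here, and the range stays wide toward lower numbers. The expected step is a 1.6-fold lower number from compound 3 to compound 4 (0.20 log units; within the scatter) in this estimate. For compound 4 the estimated value is 40 ug/mL with an expected range of 5 ug/mL to 100 ug/mL as the working figure.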

Compound 4, half-maximal inhibitory concentration: 35 ug/mL
The estimate for compound 4 lay 1.1-fold (0.06 log units) above the measured number; the measured number falls inside the stated range.
By their numbers in this assay, from the lowest: compounds 4, 3 and 2 (each within the scatter of the next, the first and the last beyond it). At a limit, above all of these: compound 1.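

Hydroxy is the first group at this carbon to give a step beyond the scatter between two measured numbers: in this assay there is a 2.1-fold lower number from compound 2 to compound 4 (0.31 log units; beyond the scatter), a modest step, whereas hydrogen and chloro could not be told apart. The comparison with chloro stays unresolved, with a 1.8-fold lower number from compound 3 to compound 4 (0.26 log units; within the scatter), so the series separates hydroxy from hydrogen but not from chloro. Removing the isopropyl from the same oxygen gives an at least 2.8-fold lower number from compound 1 to compound 4 (0.45 log units; beyond the scatter), the first floor from compound 1 to clear the scatter, and that step remains a floor only, as compound 1 stands at a limit: the limit of > 100 ug/mL in this assay, at which 1 of the 4 values shown sits.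

On these data alone, it remains open whether an amine or a carboxylic acid on this carbon would follow hydroxy or stay level with hydrogen and chloro, and whether a methoxy group here would give a number or a limit like the isopropoxy of compound 1. Also open, as far as these compounds go, is whether the step from hydrogen to hydroxy holds when the rest of the shared core changes, as all four compounds differ only at this one carbon.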